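Extending the Amide of Compound 1 with a Butyl Chain

A few compounds are considered here, and "the series" means these few. Any claim that something is new, unique, unknown or untested is made for them only; others in the source may bear on it.

Compound 1, `NC(=O)c1ccc2c(c1)S(=O)(=O)C=C2`, carries a primary amide on its core. In a functional assay on HT-29 cells (Homo sapiens) for cytotoxicity, read by MTT assay, with a stated time of 72 h (on this read-out lower numbers stand for stronger inhibition of growth and higher numbers for weaker inhibition of growth), compound 1 gives 5190 nM, the highest of the two numbers recorded here. Compound 2, `COc1ccc(NC(=O)c2ccc3c(c2)S(=O)(=O)C=C3)cc1`, has a methoxyphenyl group attached to the amide nitrogen instead, and in this assay compound 2 gives 350 nM, a value far below that of compound 1 and well beyond the scatter of repeated measurements. Among the measured compounds shown here, no single-change step between these two has been worked out, so the two values can only be read side by side: replacing the amide hydrogen with a larger group goes along with a much stronger inhibition of growth.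

Compound 3, `CCCCNC(=O)c1ccc2c(c1)S(=O)(=O)C=C2`, tests a different substituent at the same place. Relative to compound 1 the change is butyl in place of hydrogen on an amide-type nitrogen. Because the amide hydrogen in compound 1 gives 5190 nM while the substituted amide in compound 2 gives 350 nM, a drop is expected for compound 3 too, though a butyl chain shares little with a methoxyphenyl group, so the step of a 3.5-fold lower number from compound 1 to compound 3 (0.54 log units; beyond the scatter) is estimated as moderate, with real uncertainty. Compound 3 is expected to give about 1500 nM, somewhere between 450 nM and 5000 nM.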

Compound 3, concentration for 50% growth inhibition: 2320 nM
Estimate against measurement, compound 3: 1.5-fold (0.19 log units) below, within the range that was stated.
By their numbers in this assay, from the lowest: compound 2; then compound 3; then compound 1.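

Compound 3 gives a single-change reading at the amide nitrogen: in this assay, butyl in place of the amide hydrogen gives a 2.2-fold lower number from compound 1 to compound 3 (0.35 log units; beyond the scatter), so even a chain with no ring moves the number beyond the scatter, though only modestly. Substitution on this nitrogen is therefore not enough on its own to reach the lowest number here, since compound 3 gives 2320 nM while compound 2, with its methoxyphenyl group at the same place, gives 350 nM, which shows that the choice of group matters as well. Nothing available explains why the butyl chain lowers the number or why these two substituted amides sit so far apart.

Still open, going by these compounds, is whether a shorter or longer chain on this nitrogen would carry the number further down or back up, and whether the ring or the methoxy group of compound 2 goes with its lower value. A plain phenyl group on the amide nitrogen would help to separate those two parts, and a butyl chain ending in an amine or a carboxylic acid would show how much the chain tolerates.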